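Three Measured Analogues and a Fourth Awaiting Its Number

The source may hold more compounds than are shown below. What is called first, only, known or untested is meant among the compounds shown, and "the series" means these compounds.

In a functional assay on isolated protein for inhibition of Glucose-dependent insulinotropic receptor (Rattus norvegicus), read by HTRF and cAMP accumulation (a lower number here means a smaller maximal response, a higher number a larger maximal response), three compounds have been measured so far:

Compound 1, `Cc1nc(S(C)(=O)=O)ccc1Oc1ncnc(OC2CCN(C(=O)OC3COC3)CC2)c1F`, gives 66%.
Compound 2, `Cc1nc(S(C)(=O)=O)ccc1Oc1ncnc(OC2CCN(C(=O)OC3(C(F)(F)F)CCC3)CC2)c1F`, gives 82%.
Compound 3, `Cc1nc(S(C)(=O)=O)ccc1Oc1ncnc(OC2CCN(C(=O)OC3(C(F)(F)F)COC3)CC2)c1F`, gives 84%.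

Compound 3 stands highest of the three. Its nearest neighbour is compound 2, with a number 2 percentage points higher from compound 2 to compound 3 (within the scatter), a gap within the usual scatter, so the two cannot be ordered. Compound 1 lies furthest away, with a number 18 percentage points higher from compound 1 to compound 3 (beyond the scatter), a step beyond the scatter.

Compound 4, `CCC(F)(F)C(=O)N1CCC(Oc2ncnc(Oc3ccc(S(C)(=O)=O)nc3C)c2F)CC1`, differs from compound 3 in one place: 1,1-difluoropropyl in place of (3-(trifluoromethyl)oxetan-3-yl)oxy on a carbonyl carbon.

Among the measured compounds shown here, two measured steps bear on this, though only loosely. a number 16 percentage points higher from compound 1 to compound 2 (beyond the scatter) and a number 18 percentage points higher from compound 1 to compound 3 (beyond the scatter) both concern a change within a group attached to an oxygen next to the carbonyl, whereas the change to compound 4 removes that oxygen-bound group entirely and puts a chain directly on the carbonyl carbon. What the three compounds do show is that compound 1, carrying the smallest group, gave the lowest number, and compound 4 again carries the smallest group of the set. A modest fall, or no step beyond the scatter, is therefore expected in this assay.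

For compound 4 the expected value in this assay is 72%, within a range from 56% to 88%, which corresponds to an estimated step of a number 12 percentage points lower from compound 3 to compound 4 (beyond the scatter).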

Compound 4, largest response reached (reported as efficacy), in percent of the reference or control that the assay uses: 90%
The estimate for compound 4 lay 18 percentage points below the measured number; the measured number lies above the stated range.
By their numbers in this assay, from the lowest: compound 1; then compounds 2, 3 and 4 (each within the scatter of the next).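

In this assay, the place on a carbonyl carbon whose other neighbour is the amide-type nitrogen in a ring does not need an oxygen-linked ring group to give a high maximal response: putting 1,1-difluoropropyl there gives a number 6 percentage points higher from compound 3 to compound 4 (within the scatter), and the comparison with the cyclobutyl-bearing analogue gives a number 8 percentage points higher from compound 2 to compound 4 (within the scatter), so compounds 2, 3 and 4 cannot be ordered. The low number of compound 1 also now looks less like a matter of group size, since 1,1-difluoropropyl, with fewer heavy atoms than the group it replaces in compound 3, gives a number 24 percentage points higher from compound 1 to compound 4 (beyond the scatter); among these four compounds, the three with fluorine in this group stand together and compound 1, without fluorine there, stands apart, with no compound going against that split, though four compounds cannot establish it as a rule. No evidence is available on what lies behind these numbers.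

The compounds shown leave open whether the fluorine atoms matter on the chain itself, which a plain propyl group on the same carbonyl carbon would test. They also leave open how a longer chain, such as 1,1-difluorobutyl, or a small cyclic amine at this place would read in this assay.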